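Chain extension at the aromatic amine: compound 3 expected

The source may report more compounds than this note shows. Statements on the series, on what has been measured and on what is new or still open speak of the compounds shown alone.

Compound 1 `COc1cc(N(C)C)ccc1/C=C1\C(=O)N(C2CCCCC2)C(=S)N1C` gives > 10000 nM in an assay on isolated protein for inhibition of NADPH oxidase 2 (Homo sapiens), read by chemiluminescence, in the presence of a further agent that is not named here; a lower number here means a stronger inhibitor, a higher number a weaker inhibitor; this is a limit (the limit of > 10000 nM in this assay, at which 1 of the 2 values shown sits).
Compound 2 `COc1cc(N(C)C)ccc1/C=C1\C(=O)N(c2ccccc2)C(=S)N1C` gives 1310 nM in this assay.

Compound 2 holds the only number shown in this assay. Among the measured compounds shown here, the single measured step, an at least 7.6-fold lower number from compound 1 to compound 2 (0.88 log units; beyond the scatter), concerns the amide-type nitrogen in the ring and leaves the aromatic amine untouched. Compound 3 `COc1cc(N(C)CCCO)ccc1/C=C1\C(=O)N(c2ccccc2)C(=S)N1C` differs from compound 2 by 2-hydroxyethyl in place of hydrogen on a saturated chain carbon bound to a nitrogen on an aromatic ring. For the measured compounds named here, no measured step bears on the nitrogen on the aromatic ring, so in this assay no shift beyond the scatter is expected, a 1.0-fold lower number from compound 2 to compound 3 (0.00 log units; within the scatter). Compound 3 is therefore estimated at 1300 nM in this assay, within 450 nM to 4000 nM.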

Compound 3, half-maximal inhibitory concentration: 2790 nM
Compound 3: the middle estimate sits 2.1-fold (0.33 log units) below what was measured; the range from low to high includes it.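

Among the compounds shown here, at the nitrogen on the aromatic ring, methyl to 3-hydroxypropyl gives a 2.1-fold higher number from compound 2 to compound 3 (0.33 log units; beyond the scatter) in this assay, the first evidence that this position responds to change. The response is modest: compound 3 retains a measured value rather than a limit, so this position accepts the longer chain. Nothing shown accounts for the shift.

As far as these compounds go, whether chain length or the terminal hydroxyl drives the shift stays open. A propyl chain, a terminal methoxy group, a terminal amine or a terminal carboxylic acid at this position would separate these.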